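The compounds below may be only part of what the source reports. "The series", "measured", "known", "first", "only" and "open" are said of these compounds alone.

Compound 1 `N#Cc1c(-c2ccccc2)nc(SCC(=O)Nn2c(COc3ccc(Cl)cc3Cl)nc3ccccc3c2=O)[nH]c1=O`: 80.8%
Compound 2 `N#Cc1c(-c2ccc(Cl)cc2)nc(SCC(=O)Nn2c(COc3ccc(Cl)cc3Cl)nc3ccccc3c2=O)[nH]c1=O`: 61.5%
Compound 3 `O=C(CSc1nc(-c2ccccc2)c(C(=O)O)c(=O)[nH]1)Nn1c(COc2ccc(Cl)cc2Cl)nc2ccccc2c1=O`: 61.5%

In a functional assay on the whole organism (strain albino) for inhibition, with Rattus norvegicus as the target, read by paw edema, with stated times of 1 h and 0.5 h, at a dose of 100 mg/kg by the oral route (on this read-out higher numbers stand for more inhibition at the one dose given (going by the name of the read-out) and lower numbers for less inhibition), compound 1 gives 80.8%, while compound 2 gives 61.5% and compound 3 gives 61.5%. Compound 3 and compound 2 show no change at the digits shown, so nothing separates them here. The step of a number 19.3 percentage points lower from compound 1 to compound 3 (beyond the scatter) lies beyond the scatter, so compound 3 is clearly set apart from compound 1.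

Compound 4 `O=C(CSc1nc(-c2ccc(Cl)cc2)c(C(=O)O)c(=O)[nH]1)Nn1c(COc2ccc(Cl)cc2Cl)nc2ccccc2c1=O` differs from compound 3 by chloro in place of hydrogen on an aromatic carbon. Within the data shown here, one measured step bears on this: a number 19.3 percentage points lower from compound 1 to compound 2 (beyond the scatter), the same replacement on the same ring but carried out on the cyano-bearing core. That step was modest yet beyond the scatter, and it ran downward. Among the measured compounds shown here, the change from compound 3 to compound 4 is therefore expected to run downward by a comparable amount, a number 16.5 percentage points lower from compound 3 to compound 4 (beyond the scatter), with no measured pair speaking against that expectation. Compound 4 is accordingly estimated to give 45% in this assay, within a range of 28% to 62%.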

Compound 4, a percentage reported as inhibition, in the whole organism at one dose (the size of the read-out at that dose, not a potency): 51.9%
Estimate against measurement, compound 4: 6.9 percentage points below; low and high end bracket the measured number.
By their numbers in this assay, from the lowest: compounds 4, 2 and 3 (each within the scatter of the next); then compound 1.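

On the carboxy-bearing core, phenyl to 4-chlorophenyl reads as a number 9.6 percentage points lower from compound 3 to compound 4 (within the scatter) in this assay, so this change stays inside the scatter here, whereas on the cyano-bearing core it went beyond it. Even so, the two steps cannot be told apart, and the change reads alike on both cores: the same change on two cores in this assay, a number 19.3 percentage points lower (beyond the scatter) from compound 1 to compound 2 and a number 9.6 percentage points lower (within the scatter) from compound 3 to compound 4, 9.7 percentage points apart, within the scatter of two such steps. Carboxy in place of cyano now also has a reading with the 4-chlorophenyl group, a number 9.6 percentage points lower from compound 2 to compound 4 (within the scatter), and this too agrees with its counterpart on the phenyl compounds: the same change on two cores in this assay, a number 19.3 percentage points lower (beyond the scatter) from compound 1 to compound 3 and a number 9.6 percentage points lower (within the scatter) from compound 2 to compound 4, 9.7 percentage points apart, within the scatter of two such steps.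

As far as these compounds go, whether a methoxy group or an amine in place of the chloro would read differently at this position stays open. So does whether an ester or a primary amide in place of the cyano would hold the level of compound 1, and a single dose cannot speak to potency.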